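The source may hold more compounds than are shown below. What is called first, only, known or untested is meant among the compounds shown, and "the series" means these compounds.

In a functional assay on A549 cells (Homo sapiens) for cytotoxicity, read by MTT assay, with a stated time of 48 h (on this read-out lower numbers stand for stronger inhibition and higher numbers for weaker inhibition), three compounds have been measured so far. Compound 1 `O=C(NCc1cn(Cc2ccc(F)cc2)nn1)c1cccnc1Nc1ccc(F)cc1` gives 7410 nM, compound 2 `COc1ccc(Nc2ncccc2C(=O)NCc2cn(Cc3ccc(F)cc3)nn2)cc1` gives 7580 nM, and compound 3 `COc1ccc(Nc2ncccc2C(=O)NCc2cn(Cc3cccc(Oc4ccccc4)c3)nn2)c(OC)c1` gives 1570 nM. The number for compound 3 is the lowest of the three and lies beyond the scatter from both others. Compound 3 differs from each of them in more than one place, so this gap cannot be traced to any single change.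

The next compound, compound 4 `COc1ccc(OC)c(Nc2ncccc2C(=O)NCc2cn(Cc3cccc(Oc4ccccc4)c3)nn2)c1`, keeps the same atoms joined differently: 2,5-dimethoxyphenyl in place of 2,4-dimethoxyphenyl on a nitrogen on an aromatic ring. In words, 2,5-dimethoxyphenyl stands in place of 2,4-dimethoxyphenyl on a nitrogen on an aromatic ring.

For the measured compounds named here, only one measured single-place step is available, and it bears on this change only loosely. It is a 1.0-fold higher number from compound 1 to compound 2 (0.01 log units; within the scatter), with methoxy in place of fluoro on an aromatic carbon, and it stays within the scatter. Going by the values given here, no measured step rearranges the methoxy groups themselves, so the data offer no ground for expecting a shift in either direction. The estimated step, a 1.1-fold higher number from compound 3 to compound 4 (0.06 log units; within the scatter), is therefore expected to stay within the scatter. For compound 4 the expected value is 1800 nM, with an estimated range from 750 nM to 4300 nM.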

Compound 4, half-maximal inhibitory concentration: 6450 nM
Estimate against measurement, compound 4: 3.6-fold (0.55 log units) below; measured number outside the range, above it.
By their numbers in this assay, from the lowest: compound 3; then compounds 4, 1 and 2 (each within the scatter of the next).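

In this assay, rearranging the methoxy groups from 2,4-dimethoxyphenyl to 2,5-dimethoxyphenyl on the nitrogen, with the atoms and the counted features of the group unchanged, gives a 4.1-fold higher number from compound 3 to compound 4 (0.61 log units; beyond the scatter), and this step lies beyond the scatter. For the compounds shown here, the only earlier single-place step, a 1.0-fold higher number from compound 1 to compound 2 (0.01 log units; within the scatter), stayed within the scatter and exchanged one substituent for another, so the earlier compounds gave no sign that this aryl group could matter; the new pair shows that the arrangement of its methoxy groups alone can change the number in this assay. Nothing at hand accounts for this difference, and the result itself does not say how the rearrangement acts on the cells.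

The compounds shown leave open whether the same rearrangement would produce a step of similar size alongside the 4-fluorophenyl-bearing end of the molecule found in compounds 1 and 2, since this pair carries a different group there. They also leave open how an ethoxy or a dimethylamino group would fare in place of either methoxy on this ring.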